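The source may hold more compounds than are shown below. What is called first, only, known or untested is meant among the compounds shown, and "the series" means these compounds.

Compound 3 `COc1ccc(C2CC(c3ccc4ccccc4c3)=NN2C2=NC(=O)/C(=C3\C(=O)Nc4ccccc43)S2)cc1` gives 4030 nM in a functional assay on cells (Cancer cell lines, Homo sapiens) for cytotoxicity, read by sulforhodamine B assay, with a stated time of 48 h (a lower number here means a stronger inhibitor of growth, a higher number a weaker inhibitor of growth), the highest of the three numbers recorded; compound 1 `COc1ccc(C2CC(c3ccccc3)=NN2C2=NC(=O)/C(=C3\C(=O)Nc4ccc(Br)cc43)S2)cc1` gives 510 nM and compound 2 `COc1ccc(C2=NN(C3=NC(=O)/C(=C4\C(=O)Nc5ccc(Br)cc54)S3)C(c3ccc(OC)cc3)C2)cc1` gives 430 nM. Compound 4 `COc1ccc(C2CC(c3ccc4ccccc4c3)=NN2C2=NC(=O)/C(=C3\C(=O)Nc4ccc(Br)cc43)S2)cc1` differs from compound 3 by bromo in place of hydrogen on an aromatic carbon. Going by the values given here, the only single step measured, a 1.2-fold lower number from compound 1 to compound 2 (0.07 log units; within the scatter), concerns a methoxy and not a bromo, so it bears little on this change. Among the compounds with values here, compounds 1 and 3 differ in two places at once, so their values alone show only that the bromo-bearing compounds 1 and 2 sit lower than compound 3. The number for compound 4 is therefore expected to move modestly downward, by a 1.6-fold lower number from compound 3 to compound 4 (0.21 log units; within the scatter), and compound 4 is estimated at 2500 nM, within 800 nM to 8000 nM.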

Compound 4, concentration for total growth inhibition: 220 nM
Beside the measured number, compound 4's estimate is 11-fold (1.06 log units) above it, outside the stated range (below it).
By their numbers in this assay, from the lowest: compounds 4, 2 and 1 (each within the scatter of the next, the first and the last beyond it); then compound 3.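

Bromo in place of hydrogen on this aromatic carbon, with the naphthalen-2-yl group held fixed, gives an 18-fold lower number from compound 3 to compound 4 (1.26 log units; beyond the scatter), the first measured step for this change. With bromo kept, naphthalen-2-yl in place of 4-methoxyphenyl gives a 2.0-fold lower number from compound 2 to compound 4 (0.29 log units; within the scatter), and naphthalen-2-yl in place of phenyl gives a 2.3-fold lower number from compound 1 to compound 4 (0.37 log units; beyond the scatter), both far smaller steps than the one for bromo. No evidence is available that explains the size of the bromo step. Going by these compounds, whether chloro or an amine on this carbon would give a step like that of bromo stays open, as does whether the bromo step holds with phenyl or 4-methoxyphenyl in place of naphthalen-2-yl.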